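Methoxy to methyl on the aryl ring: compound 4

This account rests on a few compounds, and the source may have more. Where it says the series, first, only, none or still open, it means among the compounds named here.

Three compounds of the series carry measurements in a functional assay on C6 cells (Rattus norvegicus) for cytotoxicity, read by MTT assay, with a stated time of 24 h, tested at 200 ug/mL; a lower number here means a stronger effect, a higher number a weaker effect of the compound at the concentration tested. Compound 1 `O=C(CSc1ncccn1)N/N=c1/scc(-c2ccc(Br)cc2)n1-c1ccccc1` gives 63.2% in this assay. Compound 3 `Cn1nnnc1SCC(=O)N/N=c1/scc(-c2ccc([N+](=O)[O-])cc2)n1-c1ccccc1` gives 58.6% in this assay. Compound 2 `COc1ccc(-c2cs/c(=N/NC(=O)CSc3nnc(C)s3)n2-c2ccccc2)cc1` gives 22.2% in this assay, the lowest of the three numbers; its nearest neighbour is compound 3, whose number is higher by a gap beyond the scatter, and its furthest is compound 1, whose number is higher by a gap also beyond the scatter. Compound 2 is therefore the strongest of the three at the concentration tested. For the measured compounds named here, no pair of measured compounds differs in a single place, so no single-point step within the measured set is available.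

Compound 4 `Cc1ccc(-c2cs/c(=N/NC(=O)CSc3nnc(C)s3)n2-c2ccccc2)cc1` has not been measured in this assay. It differs from compound 2 by methyl in place of methoxy on an aromatic carbon. Methoxy leaves and methyl enters on an aromatic carbon of a six-membered aromatic ring of carbon only.

Nothing in the measured set tells how this change moves the read-out, so only a small step is expected, possibly none beyond the scatter, and if any, toward a weaker effect: the expected step is a number 10.8 percentage points higher from compound 2 to compound 4 (beyond the scatter). The estimate for compound 4 in this assay is 33%, with a range from 15% to 58%.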

Compound 4, a percentage reported as activity, at one concentration (the size of the read-out at that concentration, not a potency): 13.3%
Compound 4: the middle estimate sits 19.7 percentage points above what was measured, outside the stated range (below it).
By their numbers in this assay, from the lowest: compounds 4 and 2 (each within the scatter of the next); then compounds 3 and 1 (each within the scatter of the next).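

In this assay, for the compounds shown here, the change from 4-methoxyphenyl to 4-methylphenyl gives the only single-place comparison so far, and it reads a number 8.9 percentage points lower from compound 2 to compound 4 (within the scatter). With the rest of compound 2 held fixed, the methoxy group and its hydrogen-bond acceptor can therefore give way to methyl at this place, para to a large group, with no change in the read-out that stands clear of the scatter. No measurement of any property of these two groups accompanies the result, so the step stands without an explanation.

Still open, as far as these compounds go, is whether an amine, a carboxylic acid or a longer chain such as butoxy at this place would also stay within the scatter of compound 2. Going by these compounds alone, also open is whether methyl in place of methoxy would read the same with the side chains of compound 1 and compound 3, as one pair at a single concentration in this assay gives only one reading of this change.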